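A few compounds are considered here, and "the series" means these few. Any claim that something is new, unique, unknown or untested is made for them only; others in the source may bear on it.

In a functional assay on PC-3 cells (Homo sapiens) for cytotoxicity, read by MTT assay, with a stated time of 48 h (on this read-out lower numbers stand for stronger inhibition and higher numbers for weaker inhibition), compound 1 `O=C(O)CN1C(=O)/C(=C/c2nc3ccccc3n2Cc2ccc(Br)cc2F)SC1=S` gives 21100 nM. Compound 2 `O=C(O)CN1C(=O)/C(=C/c2nc3ccccc3n2Cc2ccccc2)SC1=S`, which carries phenyl in place of 4-bromo-2-fluorophenyl on a saturated chain carbon bound to an aromatic nitrogen, gives 10800 nM in this assay; the step of a 2.0-fold lower number from compound 1 to compound 2 (0.29 log units; within the scatter) lies within the scatter, so on the two numbers shown compound 2 and compound 1 stand together rather than apart. Compound 3 `COc1cc(Cn2c(/C=C3\SC(=S)N(CC(=O)O)C3=O)nc3ccccc32)cc(OC)c1` has not yet been measured. It differs from compound 2 as follows: 3,5-dimethoxyphenyl in place of phenyl on a saturated chain carbon bound to an aromatic nitrogen. For the measured compounds named here, the only measured step, a 2.0-fold lower number from compound 1 to compound 2 (0.29 log units; within the scatter), also exchanges the group on a saturated chain carbon bound to an aromatic nitrogen and stayed within the scatter, and no measured step involves a 3,5-dimethoxyphenyl group. One therefore expects no change beyond the scatter in this assay for compound 3, the estimated step being a 1.1-fold lower number from compound 2 to compound 3 (0.06 log units; within the scatter). Compound 3 is expected to give 9500 nM, with a range from 3500 nM to 26000 nM.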

Compound 3, half-maximal inhibitory concentration: 6370 nM
For compound 3 the middle estimate is 1.5-fold (0.17 log units) above the measured one; the measured number falls inside the stated range.
By their numbers in this assay, from the lowest: compounds 3, 2 and 1 (each within the scatter of the next, the first and the last beyond it).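

In this assay the position on a saturated chain carbon bound to an aromatic nitrogen now shows its first step beyond the scatter: a 3.3-fold lower number from compound 1 to compound 3 (0.52 log units; beyond the scatter) with 3,5-dimethoxyphenyl in place of 4-bromo-2-fluorophenyl, and that step is modest. The exchange of phenyl for 3,5-dimethoxyphenyl gives a 1.7-fold lower number from compound 2 to compound 3 (0.23 log units; within the scatter) and so does not separate the two groups, which means that only compound 1 and compound 3 stand apart. Nothing at hand accounts for this difference.

The compounds shown leave open whether a single methoxy group on the phenyl ring would stand with compound 3, and whether an amine there would take the number further. Bromine and fluorine also leave together in these steps, so the share of each in the step from compound 1 remains unknown.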